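A stereocentre flipped on the hydroxylated ring

The source may report more compounds than this note shows. Statements on the series, on what has been measured and on what is new or still open speak of the compounds shown alone.

Going by the values given here, compound 1 `CNC(=O)c1cc(C(=O)N[C@H]2[C@@H]3C[C@H](O)C[C@@H]32)n([C@@H](C)c2cccc(Cl)c2)n1` is, in an ADME assay on cells (Hepatocyte, Canis lupus familiaris) for metabolic stability, read by LC-MS (on this read-out higher numbers stand for fast clearance and lower numbers for slow clearance), the only compound of the set to give a number: compound 1 gives 8.3 mL/min. Compound 2 `CNC(=O)c1cc(C(=O)N[C@H]2[C@@H]3C[C@@H](O)C[C@@H]32)c([C@@H](C)c2ccccc2)o1` gives a value that is only a limit of the assay, < 0.65 mL/min, which is the limit of < 0.65 mL/min in this assay, at which 1 of the 3 values shown sits. Compound 3 `CNC(=O)c1cc(C(=O)N[C@H]2CC[C@H](O)CC2)c([C@@H](C)c2ccccc2)o1` likewise gives a limit, < 0.7 mL/min, which is the limit of < 0.7 mL/min in this assay, at which 1 of the 3 values shown sits. Among the compounds with values here, the one measured change, a step that the two limits leave unreadable from compound 2 to compound 3, concerns the ring on the amide-type nitrogen and cannot be read in size because both ends are limits; it does not touch the change considered here in any case.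

Compound 4 `CNC(=O)c1cc(C(=O)N[C@H]2[C@@H]3C[C@@H](O)C[C@@H]32)n([C@@H](C)c2cccc(Cl)c2)n1` differs from compound 1 only in configuration: the two compounds have the same atoms and bonds and differ only in configuration as drawn: 1 of 5 stereo elements differ; a stereocentre at a saturated ring carbon is drawn S in compound 1 and R in compound 4. Within the data shown here, no measured pair in the set separates two such epimers, so no step in this assay is known that bears on the change. The account therefore expects the step from compound 1 to compound 4 to stay within the scatter, no change at the digits printed from compound 1 to compound 4 (within the scatter). Compound 4 is estimated at 8.3 mL/min, in the range 3.5 mL/min to 20 mL/min.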

Compound 4, intrinsic clearance in a liver preparation (reported as CLH), per the amount of preparation that the assay uses: < 0.65 mL/min
Compound 4: no number, only a limit; the forecaster's own chance of this, stated with the estimate: 10%; middle value at least 12-fold (1.10 log units) from the limit.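

In this assay, flipping a single stereocentre at a saturated ring carbon gives an at least 12-fold lower number from compound 1 to compound 4 (1.10 log units; beyond the scatter), so this position proved sensitive to configuration alone, which no earlier comparison could show. The whole step belongs to that one stereocentre, since nothing else separates the two structures: the fact that compounds 1 and 4 differ only in the configuration as drawn. Compound 4 gives a limit of the assay and not a number, so the step has a floor but no measured size: the limit of < 0.65 mL/min in this assay, at which 2 of the 4 values shown sit.

Going by these compounds alone, the step between compound 2 and compound 3 still cannot be read, and it is open whether the same flip would matter on the core of compound 2, where the only values are limits. As far as these compounds go, it is also open whether an amine or a methoxy group in place of the hydroxyl on this ring would show the same dependence on configuration.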